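The compounds below may be only part of what the source reports. "The series", "measured", "known", "first", "only" and "open" are said of these compounds alone.

Of the compounds shown here, three share one core and have been tested in a functional assay on B16-F10 cells (Mus musculus) for inhibition, read by MTT assay, with a stated time of 72 h; a higher number here means a weaker inhibitor, a lower number a stronger inhibitor. Compound 1 `CC(C)c1ccc(-c2nc(SCc3cn(CC(=O)NC(=O)Nc4ccccn4)nn3)nc(Nc3cccc(C(F)(F)F)c3)c2C#N)cc1` gives 1700 nM. Compound 2 `CC(C)c1ccc(Nc2nc(SCc3cn(CC(=O)NC(=O)Nc4ccccn4)nn3)nc(-c3ccc(C(C)C)cc3)c2C#N)cc1` gives 4380 nM. Between these two lies the step of a 2.6-fold higher number from compound 1 to compound 2 (0.41 log units; beyond the scatter). Compound 3 `COc1cc(-c2nc(SCc3cn(CC(=O)NC(=O)Nc4ccccn4)nn3)nc(Nc3ccc(C(C)C)cc3)c2C#N)cc(OC)c1OC` gives 1210 nM, the lowest of the three numbers, with the step of a 3.6-fold lower number from compound 2 to compound 3 (0.56 log units; beyond the scatter) arising from the group on the ring carbon; compound 3 and compound 1 lie within the scatter of each other, so neither can be called the stronger inhibitor.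

Compound 4 `COc1cc(-c2nc(SCc3cn(CC(=O)NC(=O)Nc4ccccn4)nn3)nc(Nc3cccc(C(F)(F)F)c3)c2C#N)cc(OC)c1OC` differs from compound 3 by 3-(trifluoromethyl)phenyl in place of 4-isopropylphenyl on a nitrogen on an aromatic ring. This is the exact reverse of the change between compound 1 and compound 2, where the step was a 2.6-fold higher number from compound 1 to compound 2 (0.41 log units; beyond the scatter). Running that change backwards on compound 3 suggests a modest move toward a lower number in this assay. The group on the ring carbon differs between compound 1 and compound 3, so the size of that move is uncertain. Compound 4 is therefore expected to show a step of a 2.0-fold lower number from compound 3 to compound 4 (0.30 log units; within the scatter). For compound 4 the estimated value is 600 nM, within a range from 250 nM to 1500 nM.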

Compound 4, half-maximal inhibitory concentration: 24400 nM
The estimate for compound 4 lay 41-fold (1.61 log units) below the measured number; measured number above the stated range.
By their numbers in this assay, from the lowest: compounds 3 and 1 (each within the scatter of the next); then compound 2; then compound 4.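

In this assay, the effect of the group on the nitrogen depends on the group on the aromatic carbon: with 3,4,5-trimethoxyphenyl on that carbon, 3-(trifluoromethyl)phenyl in place of 4-isopropylphenyl gives a 20-fold higher number from compound 3 to compound 4 (1.30 log units; beyond the scatter), the opposite direction to the same exchange with 4-isopropylphenyl on the carbon: the same change on two cores in this assay, a 2.6-fold higher number (0.41 log units; beyond the scatter) from compound 1 to compound 2 and a 20-fold lower number (1.30 log units; beyond the scatter) from compound 4 to compound 3, 52-fold (1.72 log units) apart, beyond the scatter of two such steps. The dependence also holds when read from the carbon, where 3,4,5-trimethoxyphenyl in place of 4-isopropylphenyl gives a 14-fold higher number from compound 1 to compound 4 (1.16 log units; beyond the scatter) with 3-(trifluoromethyl)phenyl on the nitrogen, against a fall with 4-isopropylphenyl there: the same change on two cores in this assay, a 3.6-fold lower number (0.56 log units; beyond the scatter) from compound 2 to compound 3 and a 14-fold higher number (1.16 log units; beyond the scatter) from compound 1 to compound 4, 52-fold (1.72 log units) apart, beyond the scatter of two such steps. The two groups therefore cannot be judged one at a time, as their contributions do not simply add.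

Going by these compounds, what links the two places remains unknown. On these data alone, it is also open whether the same dependence appears with an unsubstituted phenyl or a 4-methoxyphenyl on the nitrogen.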